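The source may hold more compounds than are shown below. What is called first, only, known or untested is meant among the compounds shown, and "the series" means these compounds.

Within the data shown here, in an ADME assay on microsomes from liver (Rattus norvegicus) for metabolic stability (on this read-out higher numbers stand for a longer-lived compound and lower numbers for a shorter-lived compound), compound 1 `CC(C)C(c1ccc(-c2ccc3cccc(F)c3c2)[nH]c1=O)N1CCCCS1(=O)=O` gives 0.07 h as the only numeric reading. Compound 2 `CCn1ncc2c(F)cc(-c3ccc(C(CC)(CC)c4nnc[nH]4)c(=O)[nH]3)cc21` gives > 3 h as its reading, and this is a limit of the assay, not a number. Compound 1 therefore lies far under the limit reached by compound 2, at the short-lived end of what has been seen so far.

The change to compound 3 `CC(C)C(c1ccc(-c2ccc3cccc(F)c3c2)[nH]c1=O)N1CCN/C1=N\C#N` is a group of 8 heavy atoms (4 carbon, 4 nitrogen; one five-membered non-aromatic ring with 2 hetero atoms) in place of a group of 8 heavy atoms (4 carbon, 1 nitrogen, 2 oxygen, 1 sulfur; one six-membered non-aromatic ring with 2 hetero atoms), on a saturated chain carbon bound to an aromatic carbon and a saturated chain carbon and it leaves the rest of compound 1 untouched. Among the measured compounds shown here, compound 2 differs from compound 1 in more than one place, so no measured step bears on this swap. In this assay only a slight rise is expected, none beyond the scatter, and the estimated move is a 1.7-fold higher number from compound 1 to compound 3 (0.23 log units; within the scatter) in half-life terms. For compound 3 the estimated half-life is 0.12 h with a range from 0.04 h to 0.4 h as the expected bounds.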

Compound 3, half-life: 0.327 h
Compound 3: middle estimate off by 2.7-fold (0.44 log units), on the low side, within the range that was stated.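

Among these compounds, this is the first step read at this position, the saturated chain carbon bound to an aromatic carbon and a saturated chain carbon: in this assay, the five-membered ring group of 4 carbon and 4 nitrogen atoms in place of the six-membered ring group holding sulfur gives a 4.7-fold higher number from compound 1 to compound 3 (0.67 log units; beyond the scatter). The half-life at this position therefore responds to the group placed there, with the rest of the core of compound 1 unchanged, and the step is modest but beyond the scatter. No measurement shown gives a cause for this rise.

A single swap changes ring size and ring atoms together, so their separate contributions remain unresolved. Also open is how a morpholine, a simple amine or a carboxylic acid on this carbon would compare with the two groups shown.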